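This account rests on a few compounds, and the source may have more. Where it says the series, first, only, none or still open, it means among the compounds named here.

Of the compounds shown here, three built on one shared core have been measured in a functional assay on HT-1080 cells (Homo sapiens) for antiproliferative activity, read by sulforhodamine B assay, with a stated time of 48 h; a lower number here means a stronger inhibitor, a higher number a weaker inhibitor. Compound 1 `NS(=O)(=O)c1ccc(N/C(S)=N\c2ccnc3cc(C(F)(F)F)ccc23)cc1` gives 31000 nM, compound 2 `O=S(=O)(Nc1ncccn1)c1ccc(N/C(S)=N\c2ccnc3cc(C(F)(F)F)ccc23)cc1` gives 29100 nM, and compound 3 `Cc1cc(C)nc(NS(=O)(=O)c2ccc(N/C(S)=N\c3ccnc4cc(C(F)(F)F)ccc34)cc2)n1` gives 29500 nM. On these numbers compound 3 stands second highest of the three, with the steps of a 1.1-fold lower number from compound 1 to compound 3 (0.02 log units; within the scatter) and a 1.0-fold higher number from compound 2 to compound 3 (0.01 log units; within the scatter) both within the scatter, as is a 1.1-fold lower number from compound 1 to compound 2 (0.03 log units; within the scatter). Compound 4 `COc1cc(NS(=O)(=O)c2ccc(N/C(S)=N\c3ccnc4cc(C(F)(F)F)ccc34)cc2)nc(OC)n1` differs from compound 3 by 2,6-dimethoxypyrimidin-4-yl in place of 4,6-dimethylpyrimidin-2-yl on a sulfonamide nitrogen. Both earlier changes at the sulfonamide nitrogen, whether adding a pyrimidinyl group or altering its methyl substitution, stayed within the scatter, so the move to another substituted pyrimidinyl is expected to give no step beyond the scatter, no change at the digits printed from compound 3 to compound 4 (within the scatter). Compound 4 is therefore estimated at 29500 nM, within a range from 15000 nM to 60000 nM.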

Compound 4, half-maximal inhibitory concentration: 29500 nM
The estimate for compound 4 equals the measured number at the digits printed, within the range that was stated.
By their numbers in this assay, from the lowest: compounds 2, 3, 4 and 1 (each within the scatter of the next).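

In this assay the move to 2,6-dimethoxypyrimidin-4-yl on a sulfonamide nitrogen gives no change at the digits printed from compound 3 to compound 4 (within the scatter) even though the entering group brings oxygen atoms that the leaving group lacks. The same group gives a 1.0-fold higher number from compound 2 to compound 4 (0.01 log units; within the scatter) and also a 1.1-fold lower number from compound 1 to compound 4 (0.02 log units; within the scatter) so this position has now taken a third pyrimidinyl variant with no step beyond the scatter. Nothing available explains this flat response. Still open, as far as these compounds go, is whether a carboxylic acid or an amine on this nitrogen, or a change elsewhere on the shared core, would move the number beyond the scatter.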